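Series notes: cytotoxicity, compound 3 to compound 4

This account rests on a few compounds, and the source may have more. Where it says the series, first, only, none or still open, it means among the compounds named here.

compound 1 `CCc1ccc2[nH]c(=O)c(CN(CCCO)Cc3ccc(C(C)(C)C)cc3)cc2c1` — > 10000 nM
compound 2 `CCc1ccc2[nH]c(=O)c(CN(Cc3ccc(OC(F)F)cc3)Cc3ccc(C(C)(C)C)cc3)cc2c1` — > 5000 nM
compound 3 `Cc1ccc2[nH]c(=O)c(CN(Cc3ccc(C(C)(C)C)cc3)C(C)c3ccc(OC(F)F)cc3)cc2c1` — > 5000 nM

In a toxicity assay on MDCK cells (Canis lupus familiaris) for cytotoxicity, read by crystal violet staining, with a stated time of 48 h (on this read-out lower numbers stand for higher toxicity in this test and higher numbers for lower toxicity in this test), the value for compound 1 is a limit of the assay, (the limit of > 10000 nM in this assay, at which 1 of the 3 values shown sits). For compound 2 the value is also a limit. For compound 3 the value is likewise a limit, sitting at the limit of > 5000 nM in this assay, at which 2 of the 3 values shown sit, together with one further value. Among the compounds with values here, the step that the two limits leave unreadable from compound 1 to compound 2 is therefore unreadable, and no measured step in this set gives a number. Compound 4 `CCc1ccc2[nH]c(=O)c(CN(Cc3ccc(C(C)(C)C)cc3)C(C)c3ccc(OC(F)F)cc3)cc2c1` differs from compound 3 by methyl in place of hydrogen on a saturated chain carbon bound to an aromatic carbon. With no readable step to lean on, compound 4 is expected to remain at a limit as well, and the estimated step that the limit leaves unreadable from compound 3 to compound 4 means no change beyond the scatter. Compound 4 is estimated at 8000 nM (range 4000 nM to 20000 nM).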

Compound 4, half-maximal cytotoxic concentration: > 5000 nM
Compound 4 gave a limit, no number; the forecaster's own chance of this, stated with the estimate: 85%; the middle value is on the limit's open side.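

In this assay compound 4 gives > 5000 nM, a limit of the assay, so its steps from compound 1, compound 2 and compound 3 cannot be read. The compounds shown leave open whether methyl in place of hydrogen changes cytotoxicity at all.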